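The source may report more compounds than this note shows. Statements on the series, on what has been measured and on what is new or still open speak of the compounds shown alone.

Compound 1 `CC(=O)N(Cc1ccc(OC(C)C)cc1)c1cc(C)cc(C)c1` and compound 2 `CC(=O)N(Cc1ccc(OCc2ccccc2)cc1)c1cc(C)cc(C)c1` share one core and differ by benzyl in place of isopropyl on an oxygen on an aromatic ring. In an assay on HEK293 cells for displacement of a labelled ligand from Translocator protein (Homo sapiens), read by scintillation counting, with a stated time of 90 min (a lower number here means a stronger inhibitor, a higher number a weaker inhibitor), compound 1 gives 3150 nM, while compound 2 gives 738 nM, so that this change made a 4.3-fold lower number from compound 1 to compound 2 (0.63 log units; beyond the scatter).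

Compound 3 `CCN(CC)C(=O)CN(Cc1ccc(OC(C)C)cc1)c1cc(C)cc(C)c1` differs from compound 1 by (diethylcarbamoyl)methyl in place of acetyl on a nitrogen on an aromatic ring. In this assay compound 3 gives only > 10000 nM, which is a limit of the measurement and not a number (the limit of > 10000 nM in this assay, at which 1 of the 3 values shown sits). The change from the core of compound 1 thus made an at least 3.1-fold higher number from compound 1 to compound 3 (0.50 log units; beyond the scatter).

Compound 4 `CCN(CC)C(=O)CN(Cc1ccc(OCc2ccccc2)cc1)c1cc(C)cc(C)c1` has not yet been measured. It differs from compound 3 by benzyl in place of isopropyl on an oxygen on an aromatic ring, the same change, at the same place, as that between compound 1 and compound 2.

Compound 4 is expected to show a step of an at least 2.0-fold lower number from compound 3 to compound 4 (0.30 log units; that floor lies within the scatter) in this assay, beside the earlier 4.3-fold lower number from compound 1 to compound 2 (0.63 log units; beyond the scatter), because compound 2 gave 738 nM after the same change. Since compound 3 stands only at a limit, compound 4 is estimated near 5000 nM, between 1500 nM and 20000 nM, and may itself be reported only as a limit.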

Compound 4, inhibition constant: 1770 nM
Estimate against measurement, compound 4: 2.8-fold (0.45 log units) above; the measured number falls inside the stated range.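

In this assay, benzyl in place of isopropyl on the oxygen lowered the number on the second core as well, with an at least 5.6-fold lower number from compound 3 to compound 4 (0.75 log units; beyond the scatter), and this sits beside the earlier step: the same change on two cores in this assay, a 4.3-fold lower number (0.63 log units; beyond the scatter) from compound 1 to compound 2 and an at least 5.6-fold lower number (0.75 log units; beyond the scatter) from compound 3 to compound 4; the limit leaves it open whether they differ. The change from acetyl to (diethylcarbamoyl)methyl on the nitrogen also kept its direction with benzyl on the oxygen, with a 2.4-fold higher number from compound 2 to compound 4 (0.38 log units; beyond the scatter), and this too has an earlier counterpart: the same change on two cores in this assay, an at least 3.1-fold higher number (0.50 log units; beyond the scatter) from compound 1 to compound 3 and a 2.4-fold higher number (0.38 log units; beyond the scatter) from compound 2 to compound 4; the limit leaves it open whether they differ. Both changes thus carried their direction from one core to the other across these four compounds, but this does not show that their sizes match, and compound 3 gives > 10000 nM, which is a limit and not a number.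

The compounds shown leave open whether the same behaviour holds for other groups on the oxygen, such as a longer alkyl chain or a benzyl group bearing a carboxylic acid. They also leave open whether a chain ending in an amine on the nitrogen would follow (diethylcarbamoyl)methyl.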